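The source may report more compounds than this note shows. Statements on the series, on what has been measured and on what is new or still open speak of the compounds shown alone.

Compound 1 `COc1ccc(C2N=C(SCc3ccccc3)NC(C)=C2C(=O)Nc2ccc(F)cc2)cc1OC`: 7.2%
Compound 2 `COc1ccc(C2N=C(SCc3ccccc3Cl)NC(C)=C2C(=O)Nc2ccc(F)cc2)cc1OC`: 35.9%
Compound 3 `CC1=C(C(=O)Nc2ccc(F)cc2)C(c2ccc([N+](=O)[O-])cc2)N=C(SCc2ccccc2)N1`: 38.5%

In a functional assay on the whole organism (artery, strain albino) with Rattus norvegicus as the target, with a stated time of 300 min, at a dose of 10 mg/kg by the oral route (on this read-out lower numbers stand for less inhibition and higher numbers for more inhibition at the one dose given (going by the name of the read-out)), compound 3 gives the highest of the three numbers, with compound 2 lying within the scatter of it and compound 1 well below, the step being a number 31.3 percentage points higher from compound 1 to compound 3 (beyond the scatter). Compound 4 `CC1=C(C(=O)Nc2ccc(F)cc2)C(c2ccc([N+](=O)[O-])cc2)N=C(SCc2ccccc2Cl)N1` differs from compound 3 in one place: chloro in place of hydrogen on an aromatic carbon. One measured step is of the same kind, a number 28.7 percentage points higher from compound 1 to compound 2 (beyond the scatter), and it lay beyond the scatter. Compound 4 is therefore expected to rise further, by an estimated a number 16.5 percentage points higher from compound 3 to compound 4 (beyond the scatter), though a single precedent on a different core substituent leaves the size uncertain. For compound 4 the estimated value is 55%, with an expected range from 30% to 80%.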

Compound 4, a percentage reported as inhibition, in the whole organism at one dose (the size of the read-out at that dose, not a potency): 18.5%
Compound 4: the middle estimate sits 36.5 percentage points above what was measured; the measured number lies below the stated range.
By their numbers in this assay, from the lowest: compound 1; then compound 4; then compounds 2 and 3 (each within the scatter of the next).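

In this assay, 2-chlorobenzyl in place of benzyl has no single direction across the cores shown, giving a number 20 percentage points lower from compound 3 to compound 4 (beyond the scatter), the opposite direction to the earlier pair: the same change on two cores in this assay, a number 28.7 percentage points higher (beyond the scatter) from compound 1 to compound 2 and a number 20 percentage points lower (beyond the scatter) from compound 3 to compound 4, 48.7 percentage points apart, beyond the scatter of two such steps The other change, 4-nitrophenyl in place of 3,4-dimethoxyphenyl, also reverses once the chloro is present, giving a number 17.4 percentage points lower from compound 2 to compound 4 (beyond the scatter), so the two changes do not simply add up: the same change on two cores in this assay, a number 31.3 percentage points higher (beyond the scatter) from compound 1 to compound 3 and a number 17.4 percentage points lower (beyond the scatter) from compound 2 to compound 4, 48.7 percentage points apart, beyond the scatter of two such steps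

The compounds shown leave open whether a bromo or methoxy group at this place would follow compound 2 or compound 4 on each core. They also leave open how a 4-aminophenyl group on the saturated ring carbon would behave alongside benzyl and 2-chlorobenzyl.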